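Trading the Aminophenyl Ketone for a Difluorophenyl Ketone

This account rests on a few compounds, and the source may have more. Where it says the series, first, only, none or still open, it means among the compounds named here.

Compound 1 `COc1cc(-c2cc(/C=C/C(=O)c3ccc(N)cc3)[nH]n2)cc(OC)c1OC` was tested in a functional assay on SF-539 cells (Homo sapiens) for inhibition, read by sulforhodamine B assay, with a stated time of 48 h (a higher number here means that more compound is tolerated, a lower number that less compound is tolerated), where compound 1 gave 5420 nM. Of the two numbers recorded, this is the lower one, but the gap carries no meaning: its companion, compound 2 `COc1cc(C(=O)/C=C/c2cc(-c3cc(OC)c(OC)c(OC)c3)n[nH]2)cc(OC)c1OC`, gave 6230 nM in this assay, a difference that lies within the usual scatter. The unmeasured compound 3 `COc1cc(-c2cc(/C=C/C(=O)c3ccc(F)c(F)c3)[nH]n2)cc(OC)c1OC` keeps the shared core of compound 1 and differs only at the ketone end. The counted difference is 3,4-difluorophenyl in place of 4-aminophenyl on a carbonyl carbon. Among the compounds with values here, no step between measured compounds in this assay exists to calibrate such a change, so the expectation rests on the two values alone, and these sit close together. The step of a 1.1-fold lower number from compound 1 to compound 3 (0.04 log units; within the scatter) is expected to stay within the scatter, with no clear direction. Compound 3 is accordingly estimated at 5000 nM, within a range from 2000 nM to 14000 nM.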

Compound 3, concentration lethal to 50% of the cells: 70000 nM
Compound 3: the middle estimate sits 14-fold (1.15 log units) below what was measured; measured number outside the range, above it.
By their numbers in this assay, from the lowest: compounds 1 and 2 (each within the scatter of the next); then compound 3.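

In this assay, the ketone end of the shared core turns out to be a sensitive place: 3,4-difluorophenyl in place of 4-aminophenyl on a carbonyl carbon gives a 13-fold higher number from compound 1 to compound 3 (1.11 log units; beyond the scatter) and so puts a first measured size on a change at this position. The entering group counts no hydrogen-bond donor or acceptor where the leaving group counts one of each, but a single step cannot tell whether that difference matters. Nothing available here accounts for the size of this step.

As far as these compounds go, it remains open whether loss of the amine or arrival of the fluorines sets this number, and an unsubstituted phenyl ring on the same carbonyl carbon would help separate the two. Also open, from the compounds shown here alone, is whether a dimethylamino group or an acetamide on that ring would keep the number close to that of compound 1.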